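Compound 2 to compound 4: replacing the 4-(methylsulfanyl)phenyl group

A few compounds are considered here, and "the series" means these few. Any claim that something is new, unique, unknown or untested is made for them only; others in the source may bear on it.

Measured in a functional assay on DU-145 cells (Homo sapiens) for inhibition, read by trypan blue exclusion, with a stated time of 96 h; on this read-out lower numbers stand for stronger inhibition of growth and higher numbers for weaker inhibition of growth:
compound 1 `COc1ccc(/C=C(/Sc2ccc(C)cc2)C(=O)c2ccc(Br)cc2)cc1`: 50000 nM
compound 2 `CSc1ccc(/C=C(/SCc2ccc(C)cc2)C(=O)c2ccc(Cl)cc2)cc1`: 25000 nM
compound 3 `CSc1ccc(/C=C(/SCc2ccc(C)cc2)C(=O)c2ccc(Br)cc2)cc1`: > 100000 nM (a limit of the assay)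
Not yet measured: compound 4 `Cc1ccc(CS/C(=C/c2c[nH]c3ccc(Cl)cc23)C(=O)c2ccc(Cl)cc2)cc1`

Among the compounds with values here, compound 1 and compound 2 lie within the scatter of each other, so compound 2 stands level with compound 1 at the low end of the numbers so far. The change to compound 4 is 5-chloro-1H-indol-3-yl in place of 4-(methylsulfanyl)phenyl on a double-bonded chain carbon bound to a double-bonded chain carbon. Within the data shown here, no measured step covers this exchange. The only one is an at least 4.0-fold higher number from compound 2 to compound 3 (0.60 log units; beyond the scatter), which is bromo in place of chloro, a different change. Compound 4 keeps the chloro of compound 2, so the expectation starts from compound 2 at 25000 nM. A modest shift is expected, a 2.1-fold lower number from compound 2 to compound 4 (0.32 log units; beyond the scatter), though its direction is uncertain. For compound 4 the estimated value is 12000 nM, with an expected range of 2000 nM to 60000 nM.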

Compound 4, concentration for 50% growth inhibition: 1000 nM
The estimate for compound 4 lay 12-fold (1.08 log units) above the measured number; measured number outside the range, below it.
By their numbers in this assay, from the lowest: compound 4; then compounds 2 and 1 (each within the scatter of the next). At a limit, above all of these: compound 3.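

In this assay the place on a double-bonded chain carbon bound to a double-bonded chain carbon accepts a far larger exchange than the halogen swap seen earlier: 5-chloro-1H-indol-3-yl in place of 4-(methylsulfanyl)phenyl gives a 25-fold lower number from compound 2 to compound 4 (1.40 log units; beyond the scatter). Within the data shown here, this is the first step toward a lower number, and it is large. Nothing measured here accounts for the gain.

Open, on these data alone, is whether the gain rests on the indole rings or on their chloro. A plain 1H-indol-3-yl or a 5-methoxy-1H-indol-3-yl at this place would separate the two.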